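Swapping a Branched Chain for a Small Ring

The source may report more compounds than this note shows. Statements on the series, on what has been measured and on what is new or still open speak of the compounds shown alone.

Compound 1 `CCCCn1c(Cc2c(Br)c(OC)c(OC)c(OC)c2Br)nc2c(N)ncnc21` and compound 2 `COc1cc(Cc2nc3c(N)ncnc3n2CCCC(C)C)cc(OC)c1OC` share the same core and differ in the chain attached to it. In a functional assay on MCF7 cells (Homo sapiens) for antiproliferative activity (on this read-out lower numbers stand for stronger inhibition and higher numbers for weaker inhibition), compound 1 gives 30200 nM, while compound 2 gives 69200 nM, the highest of the two numbers and beyond the scatter from compound 1. Compound 3 `COc1cc(Cc2nc3c(N)ncnc3n2CC2CCC2)cc(OC)c1OC` changes compound 2 in one place: cyclobutyl in place of isopentyl on a saturated chain carbon bound to an aromatic nitrogen. Within the data shown here, no measured pair shows the effect of such a swap, so only a small step is expected, a 1.4-fold lower number from compound 2 to compound 3 (0.14 log units; within the scatter), leaning slightly toward stronger inhibition. Compound 3 is therefore estimated at 50000 nM, with a range from 15000 nM to 150000 nM.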

Compound 3, half-maximal inhibitory concentration: 45700 nM
Compound 3: the middle estimate sits 1.1-fold (0.04 log units) above what was measured, within the range that was stated.
By their numbers in this assay, from the lowest: compounds 1, 3 and 2 (each within the scatter of the next, the first and the last beyond it).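

In this assay, cyclobutyl in place of isopentyl on a saturated chain carbon bound to an aromatic nitrogen gives a 1.5-fold lower number from compound 2 to compound 3 (0.18 log units; within the scatter). At this position, then, a chain with no ring and a four-membered ring of carbon cannot be told apart on this read-out, even with one heavy atom fewer in the group that enters. Nothing measured here offers an explanation for this result. As far as these compounds go, what stays open is whether a group of another kind at this position, such as an amine or a carboxylic acid, or a longer chain, would shift the number beyond the scatter.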